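The source may report more compounds than this note shows. Statements on the series, on what has been measured and on what is new or still open speak of the compounds shown alone.

Compound 1 `CN(O)C(=O)c1cc2c(CO)cn(Cc3ccc(F)cc3)c2cn1` and compound 2 `CCOCCOCc1cn(Cc2ccc(F)cc2)c2cnc(C(=O)N(C)O)cc12` share a core and differ only in one side chain. In an ADME assay on CEM-SS cells (Homo sapiens) for cytotoxicity, read by XTT assay (on this read-out higher numbers stand for lower toxicity in this test and lower numbers for higher toxicity in this test), compound 1 gives > 266000 nM, which is a limit of the assay and not an exact number. Among the compounds with values here, compound 2 gives 81000 nM, the only exact number so far.

Compound 3 `CC(C)NC(=O)c1cn(Cc2ccc(F)cc2)c2cnc(C(=O)N(C)O)cc12` is built from compound 2 by one change on an aromatic carbon of the five-membered ring: isopropylcarbamoyl in place of (2-ethoxyethoxy)methyl (isopropylcarbamoyl in place of (2-ethoxyethoxy)methyl on an aromatic carbon). Within the data shown here, only one measured step bears on this, an at least 3.2-fold lower number from compound 1 to compound 2 (0.51 log units; beyond the scatter), and it came with adding the 2-ethoxyethyl group. Its size is uncertain, as it rests on (the limit of > 266000 nM in this assay, at which 1 of the 2 values shown sits). Compound 3 gives up that same chain, so the step of an at least 3.2-fold lower number from compound 1 to compound 2 (0.51 log units; beyond the scatter) suggests a drift back towards higher numbers in this assay. However, a new group of similar size takes its place, and no measured compound carries it, so only a modest shift seems reasonable. The expected change is a 1.5-fold higher number from compound 2 to compound 3 (0.17 log units; within the scatter), which would not go beyond the scatter. Compound 3 is estimated at 120000 nM, within an expected range of 40000 nM to 300000 nM.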

Compound 3, half-maximal cytotoxic concentration: > 100000 nM
Compound 3 was reported as a limit; the forecaster's own chance of this, stated with the estimate: 30%; the middle value is on the limit's open side.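

In this assay, putting isopropylcarbamoyl in place of (2-ethoxyethoxy)methyl on this aromatic carbon of the five-membered ring gives an at least 1.2-fold higher number from compound 2 to compound 3 (0.09 log units; that floor lies within the scatter), so only a floor for the change is known and that floor does not go beyond the scatter. The value of compound 3 is a limit and not an exact number, so the real size of this step stays unknown: the limit of > 100000 nM in this assay, at which 1 of the 3 values shown sits.

Within the data shown here, what this adds is a first look at a side chain of a different kind at this carbon. Isopropylcarbamoyl brings a nitrogen and a hydrogen-bond donor that (2-ethoxyethoxy)methyl does not have, and with this swap the number does not fall below that of compound 2, so this new chain shows no sign of higher toxicity in this test.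

The step between compound 1 and compound 3 cannot be read, as both values are limits. The compounds shown also leave open whether a simple amine, a carboxylic acid or a longer alkyl amide chain on this carbon would move the number clearly beyond the scatter in either direction.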